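The source may hold more compounds than are shown below. What is called first, only, known or untested is meant among the compounds shown, and "the series" means these compounds.

Measured compounds in a functional assay on HepG2 cells (Homo sapiens) for antiproliferative activity, read by MTT assay, with a stated time of 48 h; on this read-out higher numbers stand for weaker inhibition and lower numbers for stronger inhibition:
compound 1 `CCn1c(C(=O)NCCCN(C)C)ccc1C(CC)(CC)c1ccc(OCCC(O)(CC)CC)c(C)c1` gives 110 nM.
compound 2 `C#CC(C)OC(=O)c1ccc(C(CC)(CC)c2ccc(OCCC(O)(CC)CC)c(C)c2)n1CC` gives only a limit, > 50000 nM.
compound 3 `CCOC(=O)C(CC(=O)OC)NC(=O)c1ccc(C(CC)(CC)c2ccc(OCCC(O)(CC)CC)c(C)c2)n1CC` gives only a limit, > 50000 nM.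

Going by the values given here, compound 1 holds the only numerical value in the set; the other two sit at the limit of > 50000 nM in this assay, at which 2 of the 3 values shown sit. Compound 4 `CCn1c(C(=O)N(C)CCO)ccc1C(CC)(CC)c1ccc(OCCC(O)(CC)CC)c(C)c1` is still to be measured. Its change from compound 1: (2-hydroxyethyl)(methyl)amino in place of (3-(dimethylamino)propyl)amino on a carbonyl carbon. Both measured steps also alter the carbonyl carbon of compound 1: an at least 450-fold higher number from compound 1 to compound 2 (2.65 log units; beyond the scatter) and an at least 450-fold higher number from compound 1 to compound 3 (2.65 log units; beyond the scatter), each a large loss, so in the two cases seen the (3-(dimethylamino)propyl)amino group is not replaced without cost. Compound 4 keeps an amide, so a smaller loss is expected: a 27-fold higher number from compound 1 to compound 4 (1.44 log units; beyond the scatter). Compound 4 is estimated at 3000 nM, in the range 400 nM to 50000 nM.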

Compound 4, half-maximal inhibitory concentration: 510 nM
Compound 4: middle estimate off by 5.9-fold (0.77 log units), on the high side; the measured number falls inside the stated range.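

In this assay, the carbonyl carbon tolerates a replacement of (3-(dimethylamino)propyl)amino, with (2-hydroxyethyl)(methyl)amino giving only a modest loss: a 4.6-fold higher number from compound 1 to compound 4 (0.67 log units; beyond the scatter). The same group stands far from the two ester-bearing compounds, with an at least 98-fold lower number from compound 3 to compound 4 (1.99 log units; beyond the scatter) and an at least 98-fold lower number from compound 2 to compound 4 (1.99 log units; beyond the scatter), so a dimethylamino end is not required for activity in the nanomolar range here. Both of these steps start from a limit and not from a number: the limit of > 50000 nM in this assay, at which 2 of the 4 values shown sit.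

Going by these compounds, the dimethylamino end and the amide hydrogen change together, so the share of each in the modest loss stays open. A (2-hydroxyethyl)amino group or a simple N-methyl amide bearing a dimethylaminopropyl chain would separate them.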